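The compounds below may be only part of what the source reports. "The series", "measured", "known", "first", "only" and "open" are said of these compounds alone.

Measured compounds:
compound 1 `O=C1C(Nc2ccc(F)cc2)=CC(=O)c2ncccc21`: 79%
compound 2 `O=C1C(Nc2cccc(F)c2)=CC(=O)c2ncccc21`: 85%
compound 3 `O=C1C(Nc2ccc(Cl)cc2)=CC(=O)c2ncccc21`: 86%

In a functional assay on the whole organism (aorta) with Rattus norvegicus as the target (on this read-out lower numbers stand for smaller maximal responses and higher numbers for larger maximal responses), compound 3 has the highest of the three numbers, but the values of compound 1 and compound 2 both lie within the usual scatter of it, so the three are not separated. Compound 4 `O=C1C(Nc2ccc(Br)cc2)=CC(=O)c2ncccc21` differs from compound 3 by bromo in place of chloro on an aromatic carbon. Among the measured compounds shown here, the only measured step that bears on this change is the halogen exchange on the same aromatic carbon, a number 7 percentage points higher from compound 1 to compound 3 (within the scatter), which stayed within the scatter. No step beyond the scatter is therefore expected in this assay for the further halogen exchange. For compound 4 the expected step is a number 1 percentage points higher from compound 3 to compound 4 (within the scatter). Compound 4 is estimated at 87%, within a range from 78% to 96%.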

Compound 4, largest response reached (Emax), in percent of the reference or control that the assay uses: 88%
Estimate against measurement, compound 4: 1 percentage points below, within the range that was stated.
By their numbers in this assay, from the lowest: compounds 1, 2, 3 and 4 (each within the scatter of the next).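

In this assay, bromo in place of chloro gives a number 2 percentage points higher from compound 3 to compound 4 (within the scatter), and bromo in place of fluoro gives a number 9 percentage points higher from compound 1 to compound 4 (within the scatter). Fluoro, chloro and bromo on this aromatic carbon, para to a large group, are therefore not separated, even across the full set of three halogens shown there. Nothing at hand speaks to the reason for this. On these data alone, whether a non-halogen group on this carbon, such as an amine, a carboxylic acid or a methoxy group, would move the maximal response beyond the scatter remains open. As far as these compounds go, the effect of changes to the shared core also remains open.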